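Swapping an azide for a benzylamine on a nucleoside core

The source may hold more compounds than are shown below. What is called first, only, known or untested is meant among the compounds shown, and "the series" means these compounds.

Measured so far:
compound 1 `OC[C@H]1O[C@@H](n2cnc3c(NCc4ccccc4)nccc32)C[C@@H]1O` — 8%
compound 2 `CCCCCCNc1[nH]ccc2ncnc1-2` — 100%

In a functional assay on EL4 cells (Mus musculus) for inhibition, tested at 100 uM (on this read-out higher numbers stand for more inhibition at the one concentration tested (going by the name of the read-out) and lower numbers for less inhibition), compound 1 gives 8%, the lowest of the two numbers, while compound 2 on a different core gives 100%, a gap beyond the scatter. Compound 3 `[N-]=[N+]=Nc1nccc2c1ncn2[C@H]1C[C@H](O)[C@@H](CO)O1` keeps the core of compound 1 and differs only by azido in place of benzylamino on an aromatic carbon. Among the compounds with values here, no measured pair shows what this change does, so the expected step of a number 4 percentage points higher from compound 1 to compound 3 (within the scatter) is small, with no clear direction beyond the scatter. Compound 3 is therefore estimated at 12%, within -8% to 38%.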

Compound 3, a percentage reported as inhibition, at one concentration (the size of the read-out at that concentration, not a potency): 13%
The estimate for compound 3 lay 1 percentage points below the measured number; the range from low to high includes it.
By their numbers in this assay, from the lowest: compounds 1 and 3 (each within the scatter of the next); then compound 2.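

At this aromatic carbon next to the ring nitrogen, azido in place of benzylamino gives a number 5 percentage points higher from compound 1 to compound 3 (within the scatter). On the core of compound 1, removing benzylamino and its six-membered carbon ring therefore does not move the number beyond the scatter. Nothing measured here explains why the two groups read alike.

As far as these compounds go, what a plain amine or a methoxy group on this carbon would give remains open. So does whether any group at this position could move the number beyond the scatter from compound 1.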